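Trifluoromethyl on a hydroxy-bearing growth inhibitor

The compounds below may be only part of what the source reports. "The series", "measured", "known", "first", "only" and "open" are said of these compounds alone.

For the measured compounds named here, in a functional assay on A2780 cells (Homo sapiens) for inhibition, read by sulforhodamine B assay (a higher number here means a weaker inhibitor of growth, a lower number a stronger inhibitor of growth), compound 1 `c1ccc(-c2ccc(-c3ccc(-c4nc5ccccc5[nH]4)cc3)cc2)cc1` gives 32100 nM and compound 2 `FC(F)(F)c1ccc(-c2ccc(-c3ccc(-c4nc5ccccc5[nH]4)cc3)cc2)cc1` gives 100000 nM as the highest number so far. Compound 3 `Oc1cccc2[nH]c(-c3ccc(-c4ccc(-c5ccccc5)cc4)cc3)nc12` gives 41000 nM as the second highest of the three, within the scatter of compound 1 and lower than compound 2. Compound 4 `Oc1cccc2[nH]c(-c3ccc(-c4ccc(-c5ccc(C(F)(F)F)cc5)cc4)cc3)nc12` has not yet been measured. It differs from compound 3 by one change, trifluoromethyl in place of hydrogen on an aromatic carbon (trifluoromethyl in place of hydrogen on an aromatic carbon, para to a large group). The same replacement on the compound without the hydroxy gave a 3.1-fold higher number from compound 1 to compound 2 (0.49 log units; beyond the scatter) and counts as a modest step. Going by the values given here, the hydroxy replacement gave a 1.3-fold higher number from compound 1 to compound 3 (0.11 log units; within the scatter) and so offers no sign that the hydroxy alters the outcome, though no measured pair tests this directly. A modest step towards weaker inhibition is therefore expected. The expected step is a 2.4-fold higher number from compound 3 to compound 4 (0.39 log units; beyond the scatter) in this estimate. For compound 4 the estimated value is 100000 nM (expected range 50000 nM to 200000 nM).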

Compound 4, concentration for 50% growth inhibition: 6100 nM
Beside the measured number, compound 4's estimate is 16-fold (1.21 log units) above it, and the stated range ends above it.
By their numbers in this assay, from the lowest: compound 4; then compounds 1 and 3 (each within the scatter of the next); then compound 2.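

In this assay the trifluoromethyl change turns the other way once the hydroxy is present (a 6.7-fold lower number from compound 3 to compound 4 (0.83 log units; beyond the scatter)), so the direction of this change at this position depends on the core that carries it: the same change on two cores in this assay, a 3.1-fold higher number (0.49 log units; beyond the scatter) from compound 1 to compound 2 and a 6.7-fold lower number (0.83 log units; beyond the scatter) from compound 3 to compound 4, 21-fold (1.32 log units) apart, beyond the scatter of two such steps. Seen from the other side, the hydroxy replacement, which made no difference beyond the scatter on the unsubstituted core, has a large effect when trifluoromethyl is present (a 16-fold lower number from compound 2 to compound 4 (1.21 log units; beyond the scatter)): the same change on two cores in this assay, a 1.3-fold higher number (0.11 log units; within the scatter) from compound 1 to compound 3 and a 16-fold lower number (1.21 log units; beyond the scatter) from compound 2 to compound 4, 21-fold (1.32 log units) apart, beyond the scatter of two such steps. In these four compounds, then, the effect of each replacement cannot be read without knowing whether the other is present.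

The compounds shown leave open whether this reversal belongs to trifluoromethyl itself or would also appear with a nitrile, an amine or a carboxylic acid at the same place. They also leave open whether a methoxy group could stand in for the hydroxy, and they do not say why the two replacements depend on each other.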